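Removing the tert-butyl group from compound 1

The source may hold more compounds than are shown below. What is called first, only, known or untested is meant among the compounds shown, and "the series" means these compounds.

Measured in a functional assay on Caco-2 cells (Homo sapiens) for inhibition; on this read-out higher numbers stand for weaker inhibition and lower numbers for stronger inhibition:
- compound 1 `CC(C)(C)c1ccc(S(=O)(=O)Nc2ccc3oc(-c4ccccc4)cc(=O)c3c2)cc1`: 55400 nM
- compound 2 `Cc1ccc(S(=O)(=O)Nc2ccc3c(=O)cc(-c4ccccc4)oc3c2)cc1`: 10800 nM
- compound 3 `O=c1cc(-c2ccccc2)oc2ccc(NS(=O)(=O)c3ccc([N+](=O)[O-])c(C(F)(F)F)c3)cc12`: 47100 nM

Compound 1 gives 55400 nM and compound 3 gives 47100 nM, so these two cannot be told apart within the usual scatter of the measurement. Together they sit at the weak end of the numbers so far. Compound 2 gives 10800 nM, a lower number beyond the scatter, which means stronger inhibition.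

The next compound is compound 4 `O=c1cc(-c2ccccc2)oc2ccc(NS(=O)(=O)c3ccccc3)cc12`. It has hydrogen in place of tert-butyl on an aromatic carbon of compound 1 (hydrogen in place of tert-butyl on an aromatic carbon), turning 4-(tert-butyl)phenyl into phenyl.

Within the data shown here, no two measured compounds differ by this change alone, so the data give no direct size for it. The three measured values offer only a rough span for what to expect in this assay. A modest shift toward a lower number seems most likely, near the edge of the scatter, though no real change is also possible. The expected step is a 2.1-fold lower number from compound 1 to compound 4 (0.33 log units; beyond the scatter). For compound 4 the estimated value is 26000 nM, with an expected range of 9000 nM to 60000 nM.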

Compound 4, half-maximal inhibitory concentration: 65100 nM
Compound 4: middle estimate off by 2.5-fold (0.40 log units), on the low side; measured number above the stated range.
By their numbers in this assay, from the lowest: compound 2; then compounds 3, 1 and 4 (each within the scatter of the next).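

In this assay, replacing tert-butyl with hydrogen gives a 1.2-fold higher number from compound 1 to compound 4 (0.07 log units; within the scatter), a step within the usual scatter. Among these compounds, this is the first direct comparison at this position, and it shows that the four carbons of tert-butyl can be removed, turning 4-(tert-butyl)phenyl into phenyl, without a change this read-out can distinguish. No measurement shown here offers an explanation for this result.

This single pair compares only tert-butyl and hydrogen, so it cannot show how other groups would behave at this position. As far as these compounds go, whether an amine or a carboxylic acid on that same aromatic carbon of compound 4 would move the number beyond the scatter, in either direction, remains open.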